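Benzodioxinyl in place of trifluoromethylphenyl on a thienopyrimidinone-type core

A few compounds are considered here, and "the series" means these few. Any claim that something is new, unique, unknown or untested is made for them only; others in the source may bear on it.

Among the compounds with values here, compound 2 `CN(C(=O)N1CC[C@H](n2cnc3cc(-c4ccc(C(F)(F)F)cc4)sc3c2=O)C1)[C@H]1CCN(C2CCOCC2)C1` gives 19 nM in an assay on isolated protein for binding affinity to melanin-concentrating hormone receptor 1 (Homo sapiens) (a higher number here means a weaker inhibitor, a lower number a stronger inhibitor), the higher of the two numbers known so far. Compound 1 `CN(C(=O)N1CC[C@H](n2cnc3cc(-c4ccc(Cl)cc4)sc3c2=O)C1)[C@H]1CCN(CC2CC2)C1` gives 3 nM in this assay, a gap beyond the usual scatter; the two compounds differ in more than one place, so no single step accounts for it. Compound 3 `CN(C(=O)N1CC[C@H](n2cnc3cc(-c4ccc5c(c4)OCCO5)sc3c2=O)C1)[C@H]1CCN(C2CCOCC2)C1` carries 2,3-dihydro-1,4-benzodioxin-6-yl in place of 4-(trifluoromethyl)phenyl on an aromatic carbon. Within the data shown here, no measured step informs this change directly, and compound 3 is expected to stay close to compound 2, with a 1.3-fold higher number from compound 2 to compound 3 (0.12 log units; within the scatter) not beyond the scatter. Compound 3 is estimated at 25 nM, within 8 nM to 80 nM.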

Compound 3, inhibition constant: 45 nM
For compound 3 the middle estimate is 1.8-fold (0.26 log units) below the measured one; measured number inside the range.
By their numbers in this assay, from the lowest: compound 1; then compound 2; then compound 3.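

On an aromatic carbon next to the ring sulfur, 2,3-dihydro-1,4-benzodioxin-6-yl in place of 4-(trifluoromethyl)phenyl brings a 2.4-fold higher number from compound 2 to compound 3 (0.37 log units; beyond the scatter) in this assay. This position therefore responds to the group it carries, yet the step is modest, even though the entering group has 2 hydrogen-bond acceptors and the leaving group has 0. Nothing at hand explains the step. From the compounds shown here alone, what a 4-methoxyphenyl would give at this position stays open. So does whether the step would hold with the cyclopropylmethyl group of compound 1.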